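The source may report more compounds than this note shows. Statements on the series, on what has been measured and on what is new or still open speak of the compounds shown alone.

For the measured compounds named here, compound 3 `Oc1cccc(-c2cc(-c3ccc(C(F)(F)F)cc3)cc(-c3ccccc3O)n2)c1` is one of three compounds measured in a functional assay on HCT-15 cells (Homo sapiens) for inhibition; on this read-out lower numbers stand for stronger inhibition and higher numbers for weaker inhibition. For compound 3 the result is a limit of the assay, > 50000 nM. Compound 1 `Oc1ccc(-c2cc(-c3ccc(F)cc3)cc(-c3ccccc3O)n2)cc1` likewise gives only a limit, > 50000 nM. Compound 2 `Oc1cccc(-c2cc(-c3cccc(C(F)(F)F)c3)cc(-c3ccccc3O)n2)c1` gives 6460 nM, and the change from compound 2 to compound 3 weakened inhibition, an at least 7.7-fold higher number from compound 2 to compound 3 (0.88 log units; beyond the scatter), so compound 3 sits at the weak end of what was seen, at the limit of > 50000 nM in this assay, at which 2 of the 3 values shown sit.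

Compound 4 `Oc1ccc(-c2cc(-c3ccc(C(F)(F)F)cc3)cc(-c3ccccc3O)n2)cc1` differs from compound 3 by 4-hydroxyphenyl in place of 3-hydroxyphenyl on an aromatic carbon. Going by the values given here, no measured step shows this change; compound 1 carries the same 4-hydroxyphenyl group and sits at the limit. Compound 4 is therefore expected to remain at or near the limit, a step that the limit leaves unreadable from compound 3 to compound 4, with an estimated value of 80000 nM in this assay, ranging from 20000 nM to 300000 nM.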

Compound 4, half-maximal inhibitory concentration: > 50000 nM
Compound 4: a limit, no number (the forecaster's own chance of this, stated with the estimate: 85%); the middle value lies beyond the limit too.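

The steps from compound 3 to compound 4 and from compound 1 to compound 4 cannot be read, because all three compounds give only a limit: the limit of > 50000 nM in this assay, at which 3 of the 4 values shown sit.

Going by these compounds, whether 4-hydroxyphenyl in place of 3-hydroxyphenyl changes inhibition at all remains open, as does the true strength of these three compounds.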